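The compounds below may be only part of what the source reports. "The series", "measured", "known", "first", "only" and "open" are said of these compounds alone.

Measured so far:
- compound 1, `CCN(Cc1ccccc1)C(=O)C1CCN(S(=O)(=O)c2ccc(OC)cc2)CC1`: 3310 nM; 3300 nM (2 entries)
- compound 2, `CCN(Cc1ccccc1)C(=O)C1CCN(S(=O)(=O)c2c[nH]cn2)CC1`: > 10000 nM (a limit)
- compound 3, `CCN(Cc1ccccc1)C(=O)C1CCN(S(=O)(=O)c2ccc(C(F)(F)F)nc2)CC1`: > 10000 nM (a limit)

All three share one core, and they differ only in the aromatic group joined to the sulfonyl sulfur. In a functional assay on CHO cells for positive allosteric modulation of muscarinic acetylcholine receptor M5 (Homo sapiens), read by calcium flux (on this read-out higher numbers stand for an effect only at larger amounts of compound and lower numbers for an effect already at smaller amounts), compound 1 gives 3310 nM; 3300 nM (2 entries), a number. For compound 2 the result is a limit of the method, > 10000 nM, not a number. For compound 3 the result is likewise a limit, > 10000 nM. Compound 3 therefore stands at the edge of what can be measured here, together with compound 2, while compound 1 alone has a number.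

Compound 4, `CCN(Cc1ccccc1)C(=O)C1CCN(S(=O)(=O)c2ccncc2)CC1`, is not yet measured. Its change from compound 3 is pyridin-4-yl in place of 6-(trifluoromethyl)pyridin-3-yl on a sulfonyl sulfur. Going by the values given here, the only measured step that bears on this position is a step that the two limits leave unreadable from compound 2 to compound 3, and its size cannot be read, because both ends are limits, as the limit of > 10000 nM in this assay, at which 2 of the 3 values shown sit, shows. So no measured step tells how large the move to compound 4 should be in this assay.

On that basis compound 4 is expected to sit near the limit again, with the expected step that the limit leaves unreadable from compound 3 to compound 4, and an estimated value of 12000 nM between 4000 nM and 40000 nM.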

Compound 4, half-maximal effective concentration: > 10000 nM
Compound 4: no number, only a limit (the forecaster's own chance of this, stated with the estimate: 65%); the middle value lies beyond the limit too.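

In this assay compound 4 gives > 10000 nM, which is a limit and not a number. Compound 2, compound 3 and compound 4 all end at this limit, so no step among them can be read: the limit of > 10000 nM in this assay, at which 3 of the 4 values shown sit. The compounds shown leave open how far these three lie from compound 1, the only one with a number.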